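Ethoxy in Place of Trifluoromethyl: an Expected Limit

The source may hold more compounds than are shown below. What is called first, only, known or untested is meant among the compounds shown, and "the series" means these compounds.

Three amides share one core and differ only in the group on an aromatic carbon of the six-membered aromatic ring of carbon only that is part of the fused system. Compound 1 `Cc1cc(C)cc(NC(=O)COc2cc(C)nc3ccccc23)c1` carries hydrogen there. In a toxicity assay on HepG2 cells (Homo sapiens) for inhibition, read by CellTiter-Glo, with a stated time of 48 h (on this read-out higher numbers stand for weaker inhibition and lower numbers for stronger inhibition), compound 1 gives > 100000 nM, which is a limit of the assay rather than a number. Compound 2 `CSc1ccc2nc(C)cc(OCC(=O)Nc3cc(C)cc(C)c3)c2c1` carries methylsulfanyl. In this assay compound 2 gives > 100000 nM, again a limit. Compound 3 `Cc1cc(C)cc(NC(=O)COc2cc(C)nc3ccc(C(F)(F)F)cc23)c1` carries trifluoromethyl. In this assay compound 3 gives > 100000 nM, likewise a limit. Compound 3 thus stands with the other two at the limit of > 100000 nM in this assay, at which 3 of the 3 values shown sit. For the measured compounds named here, the steps among them, a step that the two limits leave unreadable from compound 1 to compound 2, a step that the two limits leave unreadable from compound 1 to compound 3 and a step that the two limits leave unreadable from compound 2 to compound 3, cannot be read, so no measured step gives a size for a change at this place.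

Compound 4 `CCOc1ccc2nc(C)cc(OCC(=O)Nc3cc(C)cc(C)c3)c2c1` differs from compound 3 by ethoxy in place of trifluoromethyl on an aromatic carbon. Hydrogen, methylsulfanyl and trifluoromethyl all left their compounds at the limit; the three unreadable steps point in no direction, and the expectation for ethoxy is the same absence of readable inhibition. Compound 4 is expected at 150000 nM, within 50000 nM to 500000 nM, most probably reported only as a limit. The expected step is a step that the limit leaves unreadable from compound 3 to compound 4, none beyond the scatter.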

Compound 4, half-maximal inhibitory concentration: > 100000 nM
Compound 4 gave a limit, no number; the forecaster's own chance of this, stated with the estimate: 85%; the middle value is on the limit's open side.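

In this assay compound 4 gives > 100000 nM, a limit and not a number. Its steps from compound 1, compound 2 and compound 3 therefore cannot be read, and all four stand together: the limit of > 100000 nM in this assay, at which 4 of the 4 values shown sit.

The compounds shown leave open whether any group at this place gives readable inhibition, and how the four compare.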